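The source may hold more compounds than are shown below. What is called first, only, known or untested is meant among the compounds shown, and "the series" means these compounds.

Measured so far:
compound 1, `CCCc1ccc(/C=C/C(=O)Nc2ccc3nc(CCC)cc(N)c3c2)cc1`, 3600 nM
compound 2, `CC(C)c1cc(N)c2cc(NC(=O)/C=C/c3ccc(C(F)(F)F)cc3)ccc2n1`, 160 nM
compound 3, `CCCc1cc(N)c2cc(NC(=O)C3CCC(c4ccc(Cl)cc4)CC3)ccc2n1`, 370 nM

These three compounds share a core and were tested in a functional assay on HEK293 cells for activation of melanin-concentrating hormone receptor 1 (Homo sapiens), read by inositol phosphate accumulation; on this read-out lower numbers stand for an effect already at smaller amounts and higher numbers for an effect only at larger amounts of compound. Compound 1 gives the highest number of the three; its gap to compound 3 and its gap to compound 2 both lie beyond the usual scatter, so compound 1 is the weakest of the measured set.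

Compound 4, `CCCc1cc(N)c2cc(NC(=O)/C=C/c3ccc(C(C)C)cc3)ccc2n1`, has not been measured. It differs from compound 1 in one place: isopropyl in place of propyl on an aromatic carbon. Among the measured compounds shown here, no measured pair shows this same change, so the expected step is uncertain. From compound 1 to compound 4 a small step toward a lower number is expected, a 2.0-fold lower number from compound 1 to compound 4 (0.30 log units; within the scatter), but it may well stay within the scatter. Compound 4 is therefore expected to give about 1800 nM, within a range from 500 nM to 6000 nM.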

Compound 4, half-maximal effective concentration: 520 nM
The estimate for compound 4 lay 3.5-fold (0.54 log units) above the measured number; low and high end bracket the measured number.
By their numbers in this assay, from the lowest: compound 2; then compounds 3 and 4 (each within the scatter of the next); then compound 1.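

Joining the same three carbons differently matters at this position: isopropyl in place of propyl gives a 6.9-fold lower number from compound 1 to compound 4 (0.84 log units; beyond the scatter) in this assay. Among the compounds shown here, the earlier compounds offered no pair differing in one place, so this is the first sign that the arrangement of the group para to a large group can shift the number beyond the scatter. Nothing available explains why this change has this effect. On these data alone, it remains open how a tert-butyl group, a cyclopropyl ring or a longer chain such as butyl would behave here. This single pair also cannot show whether the same change would act similarly on other compounds sharing the core.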